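The compounds below may be only part of what the source reports. "The series", "measured", "known", "first", "only" and "open" are said of these compounds alone.

Among the compounds with values here, compound 2 `COc1cc(-n2cccc2C(=O)N(C)C)ccc1Nc1ncc(Cl)c(Nc2ccccc2NS(C)(=O)=O)n1` stands at the lower of the two numbers so far in a functional assay on NCI-H2228 cells (Homo sapiens) for antiproliferative activity, read by MTT assay, with a stated time of 72 h (a higher number here means a weaker inhibitor, a lower number a stronger inhibitor), where compound 2 gives 54 nM. Within the data shown here, the only other measured compound, compound 1 `COc1cc(-n2cccc2C(=O)N2CCCC2)ccc1Nc1ncc(Cl)c(Nc2ccccc2NS(C)(=O)=O)n1`, differs from it by a pyrrolidin-1-yl in place of the dimethylamino on the carbonyl carbon; in this assay compound 1 gives 600 nM, and the step of an 11-fold lower number from compound 1 to compound 2 (1.05 log units; beyond the scatter) is large. Compound 3 `CCN(CC)C(=O)c1cccn1-c1ccc(Nc2ncc(Cl)c(Nc3ccccc3NS(C)(=O)=O)n2)c(OC)c1` has not yet been measured. It differs from compound 2 by diethylamino in place of dimethylamino on a carbonyl carbon. Among the measured compounds shown here, the one measured step bears on this change only indirectly: it shows that enlarging the amine on that carbonyl carbon can shift the number a great deal, and diethylamino is closer in count of heavy atoms to pyrrolidin-1-yl than to dimethylamino. The step is therefore expected to run toward a higher number, estimated as a 3.7-fold higher number from compound 2 to compound 3 (0.57 log units; beyond the scatter). Compound 3 is expected to give 200 nM in this assay, within a range from 60 nM to 800 nM.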

Compound 3, half-maximal inhibitory concentration: 870 nM
Compound 3: middle estimate off by 4.4-fold (0.64 log units), on the low side; the measured number lies above the stated range.
By their numbers in this assay, from the lowest: compound 2; then compounds 1 and 3 (each within the scatter of the next).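

In this assay, the step of a 16-fold higher number from compound 2 to compound 3 (1.21 log units; beyond the scatter) shows that the loss seen with pyrrolidin-1-yl on this carbonyl carbon also appears with an open-chain amine, so it does not require a ring. The step of a 1.5-fold higher number from compound 1 to compound 3 (0.16 log units; within the scatter) leaves compound 1 and compound 3 without a readable difference, and among these three compounds only the dimethylamino amide, compound 2, stands apart. No available evidence accounts for this sharp difference between dimethylamino and the other two amines.

The compounds shown leave open whether ethyl(methyl)amino, methylamino or azetidin-1-yl on the same carbonyl carbon would give a number close to that of compound 2 or close to that of compound 3. They also leave open whether a morpholin-4-yl or piperidin-1-yl amide would follow compound 1.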